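Three Compounds Compared for Cytotoxicity in Liver Cells

The source may hold more compounds than are shown below. What is called first, only, known or untested is meant among the compounds shown, and "the series" means these compounds.

The measured compounds and their numbers:
Compound 1, `COc1ccc(F)cc1CNCCCNc1ccnc2cc(CC3CCCCC3)ccc12`: 1830 nM
Compound 2, `COc1ccc(F)cc1CNCCCNc1ccnc2cc(-c3ccc(C(F)(F)F)cc3)ccc12`: 5190 nM

Both compounds were tested in an ADME assay on HepG2 cells (Homo sapiens) for cytotoxicity, read by luminescence, CellTiter-Glo and ATP content, with a stated time of 72 h; a higher number here means that more compound is needed for the effect, a lower number that less compound is needed. For the measured compounds named here, compound 2 has the highest of the two numbers measured so far, and its nearest neighbour is compound 1, separated by a 2.8-fold higher number from compound 1 to compound 2 (0.45 log units; beyond the scatter). That single step is the only one recorded, and it concerns the same position on the shared core that is altered next.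

Compound 3, `COc1ccc(F)cc1CNCCCNc1ccnc2cc(Oc3ccccc3OC)ccc12`, differs from compound 2 by 2-methoxyphenoxy in place of 4-(trifluoromethyl)phenyl on an aromatic carbon. Going by the values given here, no measured step involves the 2-methoxyphenoxy group, so the only guidance comes from the step of a 2.8-fold higher number from compound 1 to compound 2 (0.45 log units; beyond the scatter), which shows that exchanging the group at this position moved the number modestly. On that basis a change of similar or smaller size is expected, with no clear direction, and the step of a 1.3-fold lower number from compound 2 to compound 3 (0.11 log units; within the scatter) is estimated to stay within the scatter. Compound 3 is therefore expected to give about 4000 nM in this assay, within a range from 1500 nM to 10000 nM.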

Compound 3, half-maximal effective concentration: 6400 nM
Compound 3: the middle estimate sits 1.6-fold (0.20 log units) below what was measured, within the range that was stated.
By their numbers in this assay, from the lowest: compound 1; then compounds 2 and 3 (each within the scatter of the next).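

In this assay the exchange at this position gives a 1.2-fold higher number from compound 2 to compound 3 (0.09 log units; within the scatter), so 2-methoxyphenoxy, with its 2 hydrogen-bond acceptors, and 4-(trifluoromethyl)phenyl, with none, cannot be told apart here. The earlier compounds shown here showed only that this position responds to some exchanges, whereas this pair shows that a change in the entering group need not move the number beyond the scatter. The second new step, a 3.5-fold higher number from compound 1 to compound 3 (0.54 log units; beyond the scatter), places compound 1 apart from both other compounds, so among these three only cyclohexylmethyl, the one group without an aromatic ring, stands out, and no compound goes against this. No measurement given here accounts for these numbers.

From the compounds shown here alone, it remains open whether the separation of compound 1 rests on the cyclohexyl ring or on the carbon that links it to the shared core, which an unsubstituted phenyl or a plain cyclohexyl group at this position could help to separate. Going by these compounds, it is equally open whether an amine or a carboxylic acid here would stay with compound 2 and compound 3 or move the number further.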